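Acylation of the ring nitrogen in compound 1

The source may hold more compounds than are shown below. What is called first, only, known or untested is meant among the compounds shown, and "the series" means these compounds.

Compound 1 `CN(C)c1ccc(C2CC(c3ccc(-n4cncn4)cc3)=NN2)cc1` gives -3.3% in a functional assay on NCI-H1975 cells (Homo sapiens) for inhibition, read by sulforhodamine B assay, tested at 10 uM (a lower number here means less inhibition, a higher number more inhibition at the concentration tested (going by the name of the read-out)), the lowest of the three numbers recorded. Compound 2 `CN(C)c1ccc(C2CC(c3ccc(-n4ccnc4)cc3)=NN2)cc1` gives 0.1%, and the step of a number 3.4 percentage points higher from compound 1 to compound 2 (within the scatter) changes only the aromatic heterocycle on the aryl ring. Compound 3 `CN1CCN(c2ccc(C3=NN(S(=O)(=O)c4ccc(C#N)cc4)C(c4ccc(N(C)C)cc4)C3)cc2)CC1` gives 100%; it differs from compound 1 in more than one place, so the large gap between these two is noted without any single step being assigned to it.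

Compound 4 `COC(=O)CC(=O)N1N=C(c2ccc(-n3cncn3)cc2)CC1c1ccc(N(C)C)cc1` is the unmeasured member. Against compound 1 the change is ((methoxycarbonyl)methyl)carbonyl in place of hydrogen on an amine nitrogen in a ring. Among the measured compounds shown here, the only measured single step, a number 3.4 percentage points higher from compound 1 to compound 2 (within the scatter), lies on the aromatic ring and not on the amine nitrogen in the ring, so it does not speak to this change; it shows merely that swapping the heterocycle alone moves nothing. For the measured compounds named here, compound 3 is the one compound carrying a substituent on that nitrogen and stands far above compound 1, but its further differences prevent crediting that gap to the nitrogen alone. The expectation is therefore a rise in this assay, weakly anchored and given a wide range. Compound 4 is estimated at 35%, between -5% and 85%. The expected step from this change is a number 38.3 percentage points higher from compound 1 to compound 4 (beyond the scatter).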

Compound 4, a percentage reported as inhibition, at one concentration (the size of the read-out at that concentration, not a potency): 1.5%
Beside the measured number, compound 4's estimate is 33.5 percentage points above it, within the range that was stated.
By their numbers in this assay, from the lowest: compounds 1, 2 and 4 (each within the scatter of the next); then compound 3.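

In this assay, ((methoxycarbonyl)methyl)carbonyl in place of hydrogen on the amine nitrogen in the ring gives a number 4.8 percentage points higher from compound 1 to compound 4 (within the scatter), so this acylation leaves compound 4 indistinguishable from compound 1. Among the compounds shown here, until now, compound 3 was the only compound with a substituent on that nitrogen, and its other differences kept the role of the substitution unclear; compound 4 shows that substitution at this position is not sufficient in itself for inhibition at the concentration tested, at least with this group on the core of compound 1. No measurement available here gives a reason for the size of this step.

As far as these compounds go, what remains open is which of the differences in compound 3 accounts for its high number, whether the 4-cyanophenylsulfonyl group on the ring nitrogen, the 4-methylpiperazin-1-yl group on the aryl ring, or the two together. The compounds shown also leave open whether a different group on this nitrogen, such as a carboxylic acid in place of the methyl ester or a longer chain ending in an amine, would separate from compound 1.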